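This account rests on a few compounds, and the source may have more. Where it says the series, first, only, none or still open, it means among the compounds named here.

Compound 1 (`O=C(NO)c1ccc(/C=C/c2ccnc(-c3cccnc3)c2)cc1`) gives 4550 nM
Compound 2 (`Cc1ccc(-c2cc(/C=C/c3ccc(C(=O)NO)cc3)ccn2)cc1`) gives 1910 nM

In a functional assay on MGC-803 cells (Homo sapiens) for antiproliferative activity, read by CellTiter-Glo, with a stated time of 72 h (on this read-out lower numbers stand for stronger inhibition and higher numbers for weaker inhibition), compound 2 holds the lower of the two numbers, and compound 1 holds the higher. Compound 3 (`Cc1ccc(-c2cc(/C=C/c3ccc(C(=O)NO)cc3)c(F)cn2)cc1`) differs from compound 2 by fluoro in place of hydrogen on an aromatic carbon with fluoro in place of hydrogen on an aromatic carbon, ortho to a large group and para to a 4-methylphenyl group.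

For the measured compounds named here, only one measured step exists (a 2.4-fold lower number from compound 1 to compound 2 (0.38 log units; beyond the scatter)). It is modest and lies at another place, 4-methylphenyl in place of pyridin-3-yl. Going by the values given here, no measured compound carries fluoro, so that step gives neither size nor direction for this change. No step beyond the scatter is therefore expected in this assay on present data. The expected step (a 1.1-fold lower number from compound 2 to compound 3 (0.03 log units; within the scatter)) is small and its direction uncertain. Compound 3 is estimated at 1800 nM within an expected range (650 nM to 5000 nM).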

Compound 3, half-maximal inhibitory concentration: > 10000 nM
Compound 3 ended at the assay's limit; the forecaster's own chance of this, stated with the estimate: 2%; middle value at least 5.5-fold (0.74 log units) from the limit.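

In this assay, this aromatic carbon proves sensitive to substitution, which compounds 1 and 2 could not show, since both carry hydrogen there: fluoro in place of hydrogen gives an at least 5.2-fold higher number from compound 2 to compound 3 (0.71 log units; beyond the scatter). One fluorine atom, ortho to a large group and two atoms from the ring nitrogen, is enough for this loss of activity with the 4-methylphenyl group held constant. Compound 3 stands at a limit of the assay, not at a number: the limit of > 10000 nM in this assay, at which 1 of the 3 values shown sits.

From the compounds shown here alone, whether a chlorine, a methyl group or an amine on this carbon would behave like fluoro remains open, so the loss cannot yet be assigned to fluoro itself or to any group at this position. Also open, going by these compounds, is whether fluoro at this carbon has the same outcome with the pyridin-3-yl group of compound 1.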